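The compounds below may be only part of what the source reports. "The series", "measured", "known", "first", "only" and "open" are said of these compounds alone.

Measured so far in a functional assay on K562 cells (Homo sapiens) for antiproliferative activity, read by sulforhodamine B assay, with a stated time of 48 h, tested at 50 uM; on this read-out lower numbers stand for less inhibition and higher numbers for more inhibition at the one concentration tested (going by the name of the read-out):
- compound 1, `Cc1cc2c(C(C)C)ccc(C)c2cc1OC(=O)c1cccc(C(F)(F)F)c1`: in this assay compound 1 is reported as "not active" (no number reported), without a number.
- compound 2, `Cc1cc2c(C(C)C)ccc(C)c2cc1OC(=O)c1ccc(C(F)(F)F)cc1`: compound 2 gives 45.1%.
- compound 3, `COc1cccc(C(=O)Oc2cc3c(C)ccc(C(C)C)c3cc2C)c1`: compound 3 gives 14.2%.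

Compound 3 thus stands lowest of the two numbers; compound 2 lies well beyond the scatter above it, and compound 1 has no number at all.

Compound 4, `Cc1cc2c(C(C)C)ccc(C)c2cc1OC(=O)c1ccc([N+](=O)[O-])cc1`, is not yet measured. It differs from compound 3 in one place: 4-nitrophenyl in place of 3-methoxyphenyl on a carbonyl carbon. For the measured compounds named here, no step between measured compounds covers this change, so the direction rests only on the spread seen between compound 2 and compound 3. For compound 4 a moderate rise from compound 3 is expected, a number 15.8 percentage points higher from compound 3 to compound 4 (beyond the scatter), within a wide range. The expected inhibition for compound 4 is 30%, between 5% and 55%.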

Compound 4, a percentage reported as inhibition, at one concentration (the size of the read-out at that concentration, not a potency): 100%
For compound 4 the middle estimate is 70 percentage points below the measured one; the measured number lies above the stated range.
By their numbers in this assay, from the lowest: compound 3; then compound 2; then compound 4.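

In this assay, the group on the carbonyl carbon has a large influence: 4-nitrophenyl in place of 3-methoxyphenyl gives a number 85.8 percentage points higher from compound 3 to compound 4 (beyond the scatter). For the compounds shown here, the single swap of nitro in place of trifluoromethyl on an aromatic carbon still gives a number 54.9 percentage points higher from compound 2 to compound 4 (beyond the scatter), so the large step does not depend on the methoxy compound alone. No evidence at hand explains the size of either step.

Open, on these data alone, is whether an amine or a nitrile in place of nitro would keep this inhibition. A read-out at one concentration also leaves the potency of compound 4 open.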